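A few compounds are considered here, and "the series" means these few. Any claim that something is new, unique, unknown or untested is made for them only; others in the source may bear on it.

In an ADME assay on CCD-1095SK cells (Homo sapiens) for antiproliferative activity, read by crystal violet staining, with a stated time of 96 h (on this read-out higher numbers stand for an effect only at larger amounts of compound and lower numbers for an effect already at smaller amounts), compound 3 `O[C@H]1[C@H](Oc2ccc3ccccc3c2)OC[C@@H](O)[C@H]1O` gives 182 uM, the second highest of the three numbers. Compound 1 `O[C@H]1[C@H](Oc2ccc3ccccc3c2)OCC[C@@H]1O` gives 285 uM, a gap within the scatter of compound 3. Among the compounds with values here, compound 2 `O[C@@H]1CO[C@@H](Oc2ccc3ccccc3c2)[C@H](O)C1` gives 79 uM, and the one step recorded, a 2.3-fold higher number from compound 2 to compound 3 (0.36 log units; beyond the scatter), is the only change with a measured size. Compound 4 `O[C@@H]1[C@@H](O)[C@H](Oc2ccc3ccccc3c2)OC[C@@H]1O` has not yet been measured. It differs from compound 3 in this way: the two compounds have the same atoms and bonds and differ only in configuration as drawn: 2 of 4 stereo elements differ; a stereocentre at a saturated ring carbon is drawn R in compound 3 and S in compound 4; a stereocentre at a saturated ring carbon is drawn R in compound 3 and S in compound 4. Within the data shown here, no measured step concerns a change of configuration alone, so nothing here tells how large a move such a change produces. Among the measured compounds shown here, with no step pointing either way, compound 4 is expected to sit near compound 3 in this assay, a step of a 1.0-fold lower number from compound 3 to compound 4 (0.00 log units; within the scatter). The value of compound 4 is estimated at 180 uM, in the range 70 uM to 450 uM.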

Compound 4, concentration for half-maximal effect: 48 uM
Compound 4: middle estimate off by 3.8-fold (0.57 log units), on the high side; measured number below the stated range.
By their numbers in this assay, from the lowest: compounds 4 and 2 (each within the scatter of the next); then compounds 3 and 1 (each within the scatter of the next).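

In this assay, a change of configuration alone now has a measured size, a 3.8-fold lower number from compound 3 to compound 4 (0.58 log units; beyond the scatter), and this reading rests on one fact: the fact that compounds 3 and 4 differ only in the configuration as drawn. Hydroxy in place of hydrogen on a saturated ring carbon also no longer runs in a single direction, with a 5.9-fold lower number from compound 1 to compound 4 (0.77 log units; beyond the scatter) set against the earlier step: the same change on two cores in this assay, a 2.3-fold higher number (0.36 log units; beyond the scatter) from compound 2 to compound 3 and a 5.9-fold lower number (0.77 log units; beyond the scatter) from compound 1 to compound 4, 14-fold (1.14 log units) apart, beyond the scatter of two such steps.

The compounds shown leave open which of the two changed stereocentres carries the step, as only the pair changing together appears here. Going by these compounds, it also remains open how an amine in place of a hydroxy would read.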